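This account rests on a few compounds, and the source may have more. Where it says the series, first, only, none or still open, it means among the compounds named here.

Notes on the series. Compound 1 `O=C(CSc1ncc[nH]1)Nc1ccc2nc(NC(=O)c3ccc(C(F)(F)F)cc3)sc2c1` gives 2690 nM in a functional assay on HCT-116 cells (Homo sapiens) for antiproliferative activity, read by MTT assay, with a stated time of 72 h; a higher number here means a weaker inhibitor, a lower number a stronger inhibitor. Compound 2 `O=C(CSc1cccc(O)c1)Nc1ccc2nc(NC(=O)c3ccc(C(F)(F)F)cc3)sc2c1` gives 510 nM in this assay, and compound 3 `Cc1ccc(SCC(=O)Nc2ccc3nc(NC(=O)c4ccc(C(F)(F)F)cc4)sc3c2)c(C)c1` gives 320 nM. The three differ only in the group on the sulfur: a 5.3-fold lower number from compound 1 to compound 2 (0.72 log units; beyond the scatter) and an 8.4-fold lower number from compound 1 to compound 3 (0.92 log units; beyond the scatter), while a 1.6-fold lower number from compound 2 to compound 3 (0.20 log units; within the scatter). Compound 2 thus stands second highest of the three numbers; its nearest neighbour is compound 3, within the scatter, and its furthest is compound 1, beyond it.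

Compound 4 `Cc1ccc(C(=O)Nc2nc3ccc(NC(=O)CSc4cccc(O)c4)cc3s2)cc1` differs from compound 2 elsewhere: methyl in place of trifluoromethyl on an aromatic carbon. For the measured compounds named here, none of the measured steps touches this position; all three vary the group on the sulfur and keep the trifluoromethyl, so nothing measured speaks for or against the exchange. Going by the values given here, the only guidance is that the changes on the sulfur moved the numbers by modest amounts at most. Among the compounds with values here, with no step at this position to draw on, a change of no more than the usual scatter in this assay is expected, with no direction favoured, and the range is kept wide to reflect the lack of a precedent. Compound 4 is therefore expected to give about 700 nM, in a range of 250 nM to 2500 nM. The step this implies, a 1.4-fold higher number from compound 2 to compound 4 (0.14 log units; within the scatter), is expected to be small.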

Compound 4, half-maximal inhibitory concentration: 7730 nM
Beside the measured number, compound 4's estimate is 11-fold (1.04 log units) below it, and the stated range ends below it.
By their numbers in this assay, from the lowest: compounds 3 and 2 (each within the scatter of the next); then compound 1; then compound 4.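

In this assay, for the compounds shown here, the exchange of 4-(trifluoromethyl)phenyl for 4-methylphenyl gives a 15-fold higher number from compound 2 to compound 4 (1.18 log units; beyond the scatter) and shows that this position, unlike what the earlier compounds could say about it, is far from neutral. This single exchange outweighs every change shown on the sulfur, the largest of which is an 8.4-fold lower number from compound 1 to compound 3 (0.92 log units; beyond the scatter), so among the compounds shown the number depends more on the group at this aromatic carbon than on the group on the sulfur. The result rests on one pair, with 3-hydroxyphenyl on the sulfur, and nothing at hand explains the size of the step.

Still open, from the compounds shown here alone, is whether the same exchange costs as much with 2,4-dimethylphenyl or 1H-imidazol-2-yl on the sulfur, since the position is read here against a single sulfur group. Also open, going by these compounds, is whether trifluoromethyl is specifically needed at this carbon, or whether a chlorine, a nitrile or a methoxy group there would keep the number close to that of compound 2 at 510 nM or leave it nearer the methyl result.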